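Swapping One Ester Group for Another

A few compounds are considered here, and "the series" means these few. Any claim that something is new, unique, unknown or untested is made for them only; others in the source may bear on it.

Three compounds have been measured in a functional assay on HEK293 cells for antagonist activity at Voltage-dependent L-type calcium channel subunit alpha-1C (Oryctolagus cuniculus), read by FLIPR; a higher number here means a weaker inhibitor, a lower number a stronger inhibitor:

Compound 1 `CCOC(=O)C1=C(C)NC(COC)=C(C(=O)OC)C1c1cccc([N+](=O)[O-])c1` gives 14 nM.
Compound 2 `COC(=O)C1=C(C)NC(C)=C(C(=O)OCC(F)(F)F)C1c1cccc([N+](=O)[O-])c1` gives 16 nM.
Compound 3 `CCCCCOC(=O)C1=C(C)NC(C)=C(C(=O)OCC)C1c1cccc([N+](=O)[O-])c1` gives 49 nM.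

Compound 2 gives the second highest of these three numbers. Its value and that of compound 1 lie within the usual scatter of each other, whereas compound 3 gives a higher number that lies beyond the scatter.

Compound 4 `COC(=O)C1=C(C)NC(C)=C(C(=O)OC2Cc3ccccc3C2)C1c1cccc([N+](=O)[O-])c1` has not yet been measured in this assay. It differs from compound 2 in one place: 2,3-dihydro-1H-inden-2-yl in place of 2,2,2-trifluoroethyl on an oxygen next to a carbonyl group. For the measured compounds named here, no measured pair shows the effect of this change, so the expectation rests on compound 2 alone, whose value of 16 nM serves as the anchor. The step from compound 2 to compound 4 is expected to be small, a 1.6-fold higher number from compound 2 to compound 4 (0.19 log units; within the scatter), either towards a somewhat higher number or none beyond the scatter. Compound 4 is therefore expected to give about 25 nM, within a range from 7 nM to 90 nM.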

Compound 4, half-maximal inhibitory concentration: 72 nM
Compound 4: middle estimate off by 2.9-fold (0.46 log units), on the low side; low and high end bracket the measured number.
By their numbers in this assay, from the lowest: compounds 1 and 2 (each within the scatter of the next); then compounds 3 and 4 (each within the scatter of the next).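

Putting 2,3-dihydro-1H-inden-2-yl in place of 2,2,2-trifluoroethyl gives a 4.5-fold higher number from compound 2 to compound 4 (0.65 log units; beyond the scatter) as the first single change read at this position, so the group on this oxygen does affect the number. Even so, this group of 9 heavy atoms and two rings, replacing one of 5 heavy atoms and no ring, leaves the step modest. No evidence at hand explains the step. Still open, from the compounds shown here alone, is how a chain ending in an amine or a carboxylic acid would behave on this oxygen. Also open, going by these compounds, is whether a non-aromatic ring of similar size would give a similar step.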